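This account rests on a few compounds, and the source may have more. Where it says the series, first, only, none or still open, it means among the compounds named here.

Compound 2 `CCOC(=O)c1nn(-c2ccc(OC)cc2)/c(=N/c2nc(-c3c(C)n(C)n(-c4ccccc4)c3=O)cs2)s1` gives 13100 nM in a functional assay on A549 cells (Homo sapiens) for cytotoxicity, read by sulforhodamine B assay, with a stated time of 72 h; a higher number here means a weaker inhibitor, a lower number a stronger inhibitor. Compound 1 `CCOC(=O)c1nn(-c2ccc(C)cc2)/c(=N/c2nc(-c3c(C)n(C)n(-c4ccccc4)c3=O)cs2)s1` reaches only the limit > 100000 nM in this assay, a limit rather than a number. The step of an at least 7.6-fold higher number from compound 2 to compound 1 (0.88 log units; beyond the scatter) is the change (methyl in place of methoxy on an aromatic carbon); its size is known only as a lower bound because of the limit of > 100000 nM in this assay, at which 1 of the 3 values shown sits.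

Compound 3 `COc1ccc(/C=C2\S/C(=N\c3nc(-c4c(C)n(C)n(-c5ccccc5)c4=O)cs3)N(c3ccccc3)C2=O)cc1` gives 9100 nM in this assay; the difference between its core and that of compound 2 is not broken down here. Compound 4 `Cc1ccc(/C=C2\S/C(=N\c3nc(-c4c(C)n(C)n(-c5ccccc5)c4=O)cs3)N(c3ccccc3)C2=O)cc1` is not yet measured; it differs from compound 3 by methyl in place of methoxy on an aromatic carbon, the same change made from compound 2 to compound 1 at the same kind of place.

Compound 4 is expected to follow the step of an at least 7.6-fold higher number from compound 2 to compound 1 (0.88 log units; beyond the scatter), so an estimated step of a 5.5-fold higher number from compound 3 to compound 4 (0.74 log units; beyond the scatter) is taken, resting on one pair only. Compound 4 is therefore estimated at 50000 nM, between 15000 nM and 150000 nM.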

Compound 4, half-maximal inhibitory concentration: > 100000 nM
Compound 4 ended at the assay's limit; the forecaster's own chance of this, stated with the estimate: 40%; at least 2.0-fold (0.30 log units) between middle value and limit.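

In this assay, the change from 4-methoxyphenyl to 4-methylphenyl on the core of compound 3 gives an at least 10-fold higher number from compound 3 to compound 4 (1.04 log units; beyond the scatter). On these two cores, the change moves the number in the same direction: the same change on two cores in this assay, an at least 7.6-fold higher number (0.88 log units; beyond the scatter) from compound 2 to compound 1 and an at least 10-fold higher number (1.04 log units; beyond the scatter) from compound 3 to compound 4; the limit leaves it open whether they differ

Compound 4 gives > 100000 nM, which is a limit and not a number, so only the direction carries from one core to the other, not the size: the limit of > 100000 nM in this assay, at which 2 of the 4 values shown sit.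

The compounds shown leave open whether other groups at this place, such as ethoxy, hydroxy, chlorine or an amine, would match methoxy or fall away as methyl does. They also leave open whether the change would behave the same way on a third core.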